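Changing the Acid Side Chain: an Estimate for Compound 4

The source may report more compounds than this note shows. Statements on the series, on what has been measured and on what is new or still open speak of the compounds shown alone.

Compound 1 `CCCCC[C@](C)(O)/C=C/C1CCC(=O)[C@@H]1CCCCSCC(=O)O` gives 0.00185 mg/kg in a functional assay on the whole organism (strain Hartley) for inhibition, with Cavia porcellus as the target, with stated times of 2 min and 15 min; a lower number here means that less compound is needed, a higher number that more compound is needed for the effect.
Compound 2 `CCCCC(C)(C)[C@H](O)/C=C/C1CCC(=O)[C@@H]1CCCCSCC(=O)O` gives 0.0242 mg/kg in this assay.
Compound 3 `CCCCC[C@](C)(O)/C=C/C1CCC(=O)[C@@H]1CCCCCCC(=O)O` gives 0.00424 mg/kg in this assay.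

Compound 2 stands highest of the three, and its difference from compound 1 is not broken down here. Compound 3 differs from compound 1 by one change, (2-carboxyethyl in place of (carboxymethyl)sulfanyl on a saturated chain carbon, four bonds along the chain from a saturated ring carbon), and this gave a 2.3-fold higher number from compound 1 to compound 3 (0.36 log units; beyond the scatter). Compound 4 `CCCCC(C)(C)[C@H](O)/C=C/C1CCC(=O)[C@@H]1CCCCCCC(=O)O` has not yet been measured; it arises from compound 2 by the same change, (2-carboxyethyl in place of (carboxymethyl)sulfanyl on a saturated chain carbon, four bonds along the chain from a saturated ring carbon), at the same place. Because that change moved a 2.3-fold higher number from compound 1 to compound 3 (0.36 log units; beyond the scatter), a step of similar size is expected here, so compound 4 is estimated at 0.055 mg/kg, between 0.02 mg/kg and 0.15 mg/kg, which means an expected step of a 2.3-fold higher number from compound 2 to compound 4 (0.36 log units; beyond the scatter). This rests on a single earlier example, so the range is kept wide.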

Compound 4, dose for half-maximal effect: 0.00417 mg/kg
The estimate for compound 4 lay 13-fold (1.12 log units) above the measured number, and the stated range ends above it.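

On the core of compound 2, putting 2-carboxyethyl in place of (carboxymethyl)sulfanyl gave a 5.8-fold lower number from compound 2 to compound 4 (0.76 log units; beyond the scatter) in this assay. The same change pointed the opposite way on the core of compound 1, and the two steps clearly disagree: the same change on two cores in this assay, a 2.3-fold higher number (0.36 log units; beyond the scatter) from compound 1 to compound 3 and a 5.8-fold lower number (0.76 log units; beyond the scatter) from compound 2 to compound 4, 13-fold (1.12 log units) apart, beyond the scatter of two such steps. This shows that, in these two pairs, the outcome of the change depends on the core that carries it, so one pair is a poor guide to the other. It does not show why the two cores differ, or which direction a third core would follow.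

The compounds shown leave open how an oxygen atom in place of the sulfur, or a longer chain ending in the carboxylic acid, would behave on these two cores.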